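The source may hold more compounds than are shown below. What is called first, only, known or untested is meant among the compounds shown, and "the series" means these compounds.

Measured so far in a functional assay on A549 cells (Homo sapiens) for antiproliferative activity, read by MTT assay, with a stated time of 72 h; a higher number here means a weaker inhibitor, a lower number a stronger inhibitor:
compound 1 `O=C1C=C(N2CCN(c3ccccc3Cl)CC2)C(=O)c2ccccc21` gives 10300 nM
compound 2 `Cc1ccccc1N1CCN(C2=CC(=O)c3cccc(O)c3C2=O)CC1` gives 5300 nM
compound 3 `O=C1C=C(N2CCC(c3ccccc3)CC2)C(=O)c2c(O)cccc21` gives > 50000 nM

The values of compound 1 and compound 2 lie within the usual scatter of each other. Compound 3 has no numerical value in this assay, and its reading is a limit, > 50000 nM.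

The next compound to be tested is compound 4 `O=C1C=C(N2CCC(c3ccc(Cl)cc3)CC2)C(=O)c2c(O)cccc21`, which departs from compound 3 at a single place: chloro in place of hydrogen on an aromatic carbon. In words, this is chloro in place of hydrogen on an aromatic carbon, para to a large group, so that phenyl becomes 4-chlorophenyl.

Going by the values given here, no measured pair of compounds shows this change, so the expectation is only a loose one. Compound 1 also carries a chloro group on an aromatic ring and gives 10300 nM, so a measurable value for compound 4 seems possible, although compound 1 differs from it elsewhere too. A modest shift towards stronger inhibition is expected, estimated as an at least 1.6-fold lower number from compound 3 to compound 4 (0.22 log units; that floor lies within the scatter), and a second reading at the limit would be no surprise. For compound 4 the estimated value is 30000 nM, with an expected range from 10000 nM to 70000 nM.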

Compound 4, half-maximal inhibitory concentration: > 17200 nM
Compound 4 gave a limit, no number; the forecaster's own chance of this, stated with the estimate: 40%; the middle value is on the limit's open side.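

In this assay compound 4 gives only a limit, > 17200 nM, not a number. Compound 3 is also a limit, > 50000 nM. With a limit on each side, no step can be read between compound 3 and compound 4. The compounds shown leave open whether going from phenyl to 4-chlorophenyl changes the read-out at all, and in which direction.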